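Swapping the aryl group on a chalcone-type chain

A few compounds are considered here, and "the series" means these few. Any claim that something is new, unique, unknown or untested is made for them only; others in the source may bear on it.

Measured compounds:
- compound 1, `COc1cc(O)c(C(=O)/C=C/c2ccc(F)cc2)c(OC)c1`: "not active" (no number reported)
- compound 2, `COc1cc(OC)c(C(=O)/C=C/c2ccccc2SC)c(OC)c1`: 3%

Of the compounds shown here, two sharing one core have been tested in a functional assay on NCI-H727 cells (Homo sapiens), read by fluorescence and BrdU incorporation, with a stated time of 48 h, tested at 25 uM; a higher number here means a weaker effect of the compound at the concentration tested, a lower number a stronger effect. Compound 1 is reported in this assay as "not active" (no number reported), with no number behind it. Compound 2 gives 3% in this assay, the only number shown, and a low reading of this kind means a strong effect at the concentration tested.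

Compound 3, `COc1cccc(/C=C/C(=O)c2c(OC)cc(OC)cc2OC)c1`, has not yet been measured. It differs from compound 2 in one place: 3-methoxyphenyl in place of 2-(methylsulfanyl)phenyl on a double-bonded chain carbon bound to a double-bonded chain carbon. Within the data shown here, no measured pair shows what such a swap does here, so the size of the step is uncertain. A weaker effect than compound 2 shows, that is a rise beyond the scatter, is what is expected for the step of a number 17 percentage points higher from compound 2 to compound 3 (beyond the scatter). Compound 3 is therefore estimated at 20%, within a range from 2% to 60%.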

Compound 3, a percentage reported as activity, at one concentration (the size of the read-out at that concentration, not a potency): 5.1%
Compound 3: the middle estimate sits 14.9 percentage points above what was measured, within the range that was stated.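

In this assay, putting 3-methoxyphenyl in place of 2-(methylsulfanyl)phenyl on this chain carbon gives a number 2.1 percentage points higher from compound 2 to compound 3 (within the scatter), so the two compounds cannot be told apart in this read-out. Among these compounds, this is the first sign that this position accepts a change of aryl group without a measurable loss of the strong effect, and that the sulfur-bearing group is not needed for that effect, at least when the oxygen-bearing 3-methoxyphenyl takes its place. No measurement shown explains why these two groups read alike.

As far as these compounds go, it remains open whether the strong effect would survive if the aryl ring carried an amine or a carboxylic acid. Compound 1 differs from these compounds in more than one place, so it cannot show what any single change does.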